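Swapping Fluoro for Cyano on the Phenyl Ring

The compounds below may be only part of what the source reports. "The series", "measured", "known", "first", "only" and "open" are said of these compounds alone.

Compound 1 `O=[N+]([O-])c1ccc(CN2CCC(n3cc(CC(OCc4cc(-c5ccccc5)no4)c4ccc(Br)cc4)nn3)CC2)cc1` gives > 25000 nM in an ADME assay on cells (Fibroblast, Homo sapiens) for cytotoxicity, with a stated time of 48 h (a lower number here means a stronger inhibitor, a higher number a weaker inhibitor), which is a limit of the assay.
Compound 2 `O=[N+]([O-])c1ccc(CN2CCC(n3cc(CC(OCc4cc(-c5ccc(F)cc5)no4)c4ccc(Br)cc4)nn3)CC2)cc1` gives > 25000 nM in this assay, also a limit of the assay.
Compound 3 `O=[N+]([O-])c1ccc(CN2CCC(n3cc(CC(OCc4cc(-c5cccc(F)c5)no4)c4ccc(Br)cc4)nn3)CC2)cc1` gives 10000 nM in this assay.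

Going by the values given here, compound 3 therefore holds the only true number among the three; the other two values are limits (the limit of > 25000 nM in this assay, at which 2 of the 3 values shown sit). The steps of an at least 2.5-fold lower number from compound 1 to compound 3 (0.39 log units; beyond the scatter) and an at least 2.5-fold lower number from compound 2 to compound 3 (0.39 log units; beyond the scatter) show that the 3-fluorophenyl gives a lower number than phenyl or 4-fluorophenyl. Compound 4 `N#Cc1cccc(-c2cc(COC(Cc3cn(C4CCN(Cc5ccc([N+](=O)[O-])cc5)CC4)nn3)c3ccc(Br)cc3)on2)c1` differs from compound 3 by cyano in place of fluoro on an aromatic carbon. Among the compounds with values here, no measured step exchanges a fluoro for a cyano, so those two steps give only indirect guidance. A step within the usual scatter is expected, a 1.2-fold higher number from compound 3 to compound 4 (0.08 log units; within the scatter). Compound 4 is estimated at 12000 nM in this assay, with a range from 4000 nM to 30000 nM.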

Compound 4, half-maximal inhibitory concentration: > 25000 nM
Compound 4 ended at the assay's limit; the forecaster's own chance of this, stated with the estimate: 40%; middle value at least 2.0-fold (0.31 log units) away from the limit.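

In this assay, cyano in place of fluoro gives an at least 2.5-fold higher number from compound 3 to compound 4 (0.39 log units; beyond the scatter), so the lower number seen with 3-fluorophenyl does not carry over to 3-cyanophenyl. Of the groups shown at this place, only the fluoro of compound 3 gives a value that is not a limit of the assay: the limit of > 25000 nM in this assay, at which 3 of the 4 values shown sit.
The steps from compound 1 and from compound 2 to compound 4 cannot be read, as both ends of each are limits.

As far as these compounds go, whether an amine or a carboxylic acid in place of the fluoro would give a lower number stays open. So does how far the compounds at the limit lie from one another.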